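The source may report more compounds than this note shows. Statements on the series, on what has been measured and on what is new or still open speak of the compounds shown alone.

Working notes on the series. In a functional assay on HCT-15 cells (Homo sapiens) for inhibition (a lower number here means a stronger inhibitor, a higher number a weaker inhibitor), compound 1 `Oc1ccc(-c2cc(-c3cccc(F)c3)cc(-c3ccccc3O)n2)cc1` reaches only a limit of the assay, > 50000 nM. Compound 2 `Oc1ccc(-c2cc(-c3cccc(F)c3)cc(-c3cccc(O)c3)n2)cc1` gives 3070 nM in this assay, hence an at least 16-fold lower number from compound 1 to compound 2 (1.21 log units; beyond the scatter). That step is only a minimum because compound 1 sits at the limit of > 50000 nM in this assay, at which 1 of the 3 values shown sits. Compound 3 `Oc1ccc(-c2cc(-c3ccccc3F)cc(-c3ccc(O)cc3)n2)cc1` gives 8180 nM in this assay, the highest of the two numbers shown, with compound 2 nearest and lower by a gap beyond the scatter.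

Compound 4 `Oc1ccc(-c2cc(-c3cccc(F)c3)cc(-c3ccc(O)cc3)n2)cc1` differs from compound 3 only in the fluorophenyl group: 3-fluorophenyl in place of 2-fluorophenyl on an aromatic carbon. Among the compounds with values here, no measured step relocates the fluorine. Within the data shown here, the one measured step, from compound 1 to compound 2, relocates a hydroxyl and is large, so it shows only that repositioning a ring substituent on this core can shift the number strongly; it does not fix the direction here. Among the measured compounds shown here, compound 2 carries the same 3-fluorophenyl group as compound 4 and gives a lower number than compound 3, but the two also differ in a hydroxyphenyl group, so that pair yields no clean step.

Compound 4 is expected to give 5000 nM in this assay, with a range from 1500 nM to 16000 nM. That estimate corresponds to a 1.6-fold lower number from compound 3 to compound 4 (0.21 log units; within the scatter).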

Compound 4, half-maximal inhibitory concentration: > 50000 nM
Compound 4: only a limit was reported (the forecaster's own chance of this, stated with the estimate: 8%); at least 10-fold (1.00 log units) between middle value and limit.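

In this assay, the position opposite the ring nitrogen now has a measured step, and the fluorine placement matters there: an at least 6.1-fold higher number from compound 3 to compound 4 (0.78 log units; beyond the scatter). With the 3-fluorophenyl group held constant, the hydroxyl placement also reads in a second direction, an at least 16-fold higher number from compound 2 to compound 4 (1.21 log units; beyond the scatter), so among the compounds carrying that group, only the 3-hydroxyphenyl compound 2 gives a number short of the limit. Compound 4 is a limit and not a number, so both steps are minimum sizes, and the step between compound 1 and compound 4 cannot be read: the limit of > 50000 nM in this assay, at which 2 of the 4 values shown sit.

On these data alone, how far compound 4 lies past the limit stays open, and with it the full size of both steps. Also open, as far as these compounds go, is whether an amine or a methoxy group in place of the hydroxyl on the 3-hydroxyphenyl group of compound 2 would keep a number short of the limit.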